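Notes on chain shortening from compound 2 to compound 4

A few compounds are considered here, and "the series" means these few. Any claim that something is new, unique, unknown or untested is made for them only; others in the source may bear on it.

Among the compounds with values here, in a functional assay on MDA-MB-231 cells (Homo sapiens) for cytotoxicity, read by MTT assay, with a stated time of 24 h (a lower number here means a stronger inhibitor, a higher number a weaker inhibitor), compound 1 `CCCCCCCCCCCC(=O)Nc1nnc(S[C@@H]2O[C@H](COC(C)=O)[C@H](OC(C)=O)[C@H](OC(C)=O)[C@H]2OC(C)=O)s1` reads 26700 nM and compound 3 `CCCCCCCC/C=C\CCCCCCCC(=O)Nc1nnc(S[C@@H]2O[C@H](COC(C)=O)[C@H](OC(C)=O)[C@H](OC(C)=O)[C@H]2OC(C)=O)s1` reads 23600 nM as the two lowest numbers so far. Compound 2 `CCCCCCCCCCCCCCCCCC(=O)Nc1nnc(S[C@@H]2O[C@H](CO)[C@H](O)[C@H](O)[C@H]2O)s1` stands highest of the three at 67100 nM and its gap to each of the others lies beyond the scatter. Compound 4 `CCCCCCCC(=O)Nc1nnc(S[C@@H]2O[C@H](CO)[C@H](O)[C@H](O)[C@H]2O)s1` differs from compound 2 through hydrogen in place of decyl on a saturated chain carbon, seven bonds along the chain from a carbonyl carbon and in nothing else.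

Within the data shown here, the one measured chain step is a 1.1-fold lower number from compound 1 to compound 3 (0.05 log units; within the scatter) with dec-1-en-1-yl in place of butyl at that chain carbon, and it lies within the scatter. That step is only indirect support: it lengthens the chain rather than shortening it, and both of its compounds carry acetate esters that compound 2 and compound 4 lack. Among the measured compounds shown here, no measured pair shows a chain change without those esters. On this evidence no change beyond the scatter is expected in this assay with a slight lean toward a higher number. The step expected is a 1.2-fold higher number from compound 2 to compound 4 (0.08 log units; within the scatter) on this reasoning. For compound 4 the estimated value is 80000 nM within an expected range of 30000 nM to 200000 nM for now.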

Compound 4, half-maximal inhibitory concentration: 30800 nM
Beside the measured number, compound 4's estimate is 2.6-fold (0.41 log units) above it, within the range that was stated.
By their numbers in this assay, from the lowest: compounds 3, 1 and 4 (each within the scatter of the next); then compound 2.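

In this assay, hydrogen in place of decyl on this saturated chain carbon gives a 2.2-fold lower number from compound 2 to compound 4 (0.34 log units; beyond the scatter), a modest change that lies beyond the scatter. Within the data shown here, this is the first chain change read without the acetate esters, whereas the only earlier chain step, a 1.1-fold lower number from compound 1 to compound 3 (0.05 log units; within the scatter), lies within the scatter and was read with those esters present. Nothing at hand explains the step.

Only two chain lengths are shown without the acetate esters, so these two compounds establish no steady relation between chain length and the number in this assay. Going by these compounds, it remains open how ethyl, a chain of intermediate length, an amine or a carboxylic acid in place of decyl at this chain carbon would read.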